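The compounds below may be only part of what the source reports. "The series", "measured", "known", "first", "only" and "open" are said of these compounds alone.

Compound 1 `Cc1ccc(-n2nncc2CN2C(=O)C3(C(C#N)=C(N)Oc4c3c3nc5ccccc5nc3c3ccccc43)c3ccccc32)cc1Cl` gives > 50000 nM in a functional assay on MCF7 cells (Homo sapiens) for antiproliferative activity, read by MTT assay, with a stated time of 48 h (a lower number here means a stronger inhibitor, a higher number a weaker inhibitor), which is a limit of the assay.
Compound 2 `Cc1ccc(Cl)cc1-n1nncc1CN1C(=O)C2(C(C#N)=C(N)Oc3c2c2nc4ccccc4nc2c2ccccc32)c2ccccc21` gives > 50000 nM, again a limit.
Compound 3 `Cc1ccc(-n2nncc2CN2C(=O)C3(C(C#N)=C(N)Oc4c(N)cc5nc6ccccc6nc5c43)c3ccccc32)cc1Cl` gives > 50000 nM, also a limit.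

All three values sit at the same limit (the limit of > 50000 nM in this assay, at which 3 of the 3 values shown sit). The change from compound 1 to compound 2, (5-chloro-2-methylphenyl in place of 3-chloro-4-methylphenyl on an aromatic nitrogen), therefore gives a step whose size cannot be read: a step that the two limits leave unreadable from compound 1 to compound 2. Compound 4 `Cc1ccc(Cl)cc1-n1nncc1CN1C(=O)C2(C(C#N)=C(N)Oc3c(N)cc4nc5ccccc5nc4c32)c2ccccc21` has not been measured yet. It differs from compound 3 by the same change, (5-chloro-2-methylphenyl in place of 3-chloro-4-methylphenyl on an aromatic nitrogen). The difference between the core of compound 1 and the core of compound 3 is not broken down here. Because all measured compounds sit at the limit (the limit of > 50000 nM in this assay, at which 3 of the 3 values shown sit), the step from compound 3 to compound 4 is expected to stay unreadable, a step that the limit leaves unreadable from compound 3 to compound 4. Compound 4 is expected to give 70000 nM, most likely again as a limit, within 25000 nM to 250000 nM.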

Compound 4, half-maximal inhibitory concentration: 43500 nM
Compound 4: the middle estimate sits 1.6-fold (0.21 log units) above what was measured; the measured number falls inside the stated range.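

Putting 5-chloro-2-methylphenyl in place of 3-chloro-4-methylphenyl on the aromatic nitrogen gives, in this assay, an at least 1.1-fold lower number from compound 3 to compound 4 (0.06 log units; that floor lies within the scatter). As far as these compounds go, the same change on the core of compound 1 gives a step that cannot be read, so it stays unknown whether the change carries over from one core to the other: the limit of > 50000 nM in this assay, at which 3 of the 4 values shown sit. Compound 4 gives a true number while compound 3 stays at a limit, so the real step could be larger, but its smallest possible size lies within the usual scatter and shows no clear gain.

The compounds shown leave open how an amine or a carboxylic acid on the phenyl ring would fare in this assay. From the compounds shown here alone, a longer chain in place of the methyl also remains open.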